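Allyl on the Oxygen of Compound 2

A few compounds are considered here, and "the series" means these few. Any claim that something is new, unique, unknown or untested is made for them only; others in the source may bear on it.

In a functional assay on HUVEC cells (Homo sapiens) for antiproliferative activity, read by MTT assay, with a stated time of 24 h (on this read-out lower numbers stand for stronger inhibition and higher numbers for weaker inhibition), compound 1 (`C=CCc1cc(-c2cccc([N+](=O)[O-])c2)ccc1OC`) gives > 100000 nM, which is a limit of the assay and not a number. Compound 2 (`C=CCc1cc(-c2cccc([N+](=O)[O-])c2)ccc1O`), which carries a free hydroxy group, gives > 100000 nM, and this too is a limit. For the measured compounds named here, compound 2 therefore has no measured number of its own, and the series so far offers only (the limit of > 100000 nM in this assay, at which 2 of the 2 values shown sit).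

Compound 3 (`C=CCOc1ccc(-c2cccc([N+](=O)[O-])c2)cc1CC=C`) follows from compound 2 by a single change at that oxygen, hydroxy to allyloxy: allyl in place of hydrogen on an oxygen on an aromatic ring. It places allyl in the spot held by hydrogen on an oxygen on an aromatic ring.

Going by the values given here, only one measured step bears on this change, and it lies on the same oxygen: a step that the two limits leave unreadable from compound 1 to compound 2. That step offers no size to carry over, so no step beyond the scatter is expected in this assay. The expected outcome is a number no higher from compound 2 to compound 3 (the limit leaves the size open). The assay will most likely report only a limit again. As a value, compound 3 is estimated at 100000 nM, with an expected range from 40000 nM to 200000 nM.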

Compound 3, half-maximal inhibitory concentration: > 100000 nM
Compound 3: only a limit was reported; the forecaster's own chance of this, stated with the estimate: 75%; the middle value lies on the limit itself.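

In this assay compound 3 gives > 100000 nM, which is again a limit of the assay and not a number. Neither the step from compound 2 to compound 3 nor the step from compound 1 to compound 3 can be read. The compounds shown leave open whether any group on that oxygen would give a measurable number in this assay.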